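A few compounds are considered here, and "the series" means these few. Any claim that something is new, unique, unknown or untested is made for them only; others in the source may bear on it.

Compound 3, `CN[C@H](CNc1cc(F)c(S(=O)(=O)Nc2ncc(F)s2)cc1Cl)CC12CC(C1)C2`, is one of a small set that sits almost entirely at the edge of an ADME assay on HEK293 cells for inhibition of sodium channel protein type 8 subunit alpha (Homo sapiens), read by patch clamp, with a stated time of 5 min; on this read-out higher numbers stand for weaker inhibition and lower numbers for stronger inhibition. In this assay compound 3 gives > 34000 nM, a limit of the assay rather than a number. Compound 1, `CN[C@H](CNc1cc(F)c(S(=O)(=O)Nc2ncc(F)s2)cc1Cl)CC1CCC1`, likewise gives > 34000 nM in this assay, again a limit. Compound 2, `O=S(=O)(Nc1nccs1)c1cc(Cl)c(NCC2CCCN2)cc1F`, gives > 34000 nM; > 34000 nM (2 entries) in this assay, both entries being limits. The step that the two limits leave unreadable from compound 1 to compound 3 therefore cannot be read. Compound 4, `CN[C@H](CNc1cc(F)c(S(=O)(=O)Nc2ncc(F)s2)cc1Cl)CC1CC1`, differs from compound 3 by a group of 3 heavy atoms (3 carbon; one three-membered non-aromatic ring of carbon only) in place of a group of 5 heavy atoms (5 carbon; 2 four-membered non-aromatic rings of carbon only), on a saturated chain carbon, two bonds along the chain from an amine nitrogen. Among the measured compounds shown here, no measured step bears on this change, and the limit of > 34000 nM in this assay, at which 2 of the 3 values shown sit, shows where the set stands. Compound 4 is thus expected to behave like its neighbours, with a step that the limit leaves unreadable from compound 3 to compound 4 no larger than the scatter, so compound 4 is estimated at 40000 nM, between 15000 nM and 110000 nM.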

Compound 4, half-maximal inhibitory concentration: > 34000 nM
Compound 4: a limit, no number (the forecaster's own chance of this, stated with the estimate: 80%); the middle value lies beyond the limit too.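

Compound 4 also gives only a limit, so the steps to it from compound 1 and compound 3 cannot be read. The compounds shown leave open how strongly any of them acts in this assay, and whether the cyclopropyl, cyclobutyl or other group matters at all: the limit of > 34000 nM in this assay, at which 3 of the 4 values shown sit.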